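The source may report more compounds than this note shows. Statements on the series, on what has been measured and on what is new or still open speak of the compounds shown alone.

Three compounds of the series carry measurements in a physicochemical assay for acid dissociation. Compound 1 `COc1ccccc1Oc1ccc2c(NCCCNCc3ccco3)ccnc2c1` gives 9.28. Compound 2 `CC(C)Cc1ccc2c(NCCCNCc3ccco3)ccnc2c1` gives 9.47, and compound 3 `CC(C)CCc1ccc2c(NCCCNCc3ccco3)ccnc2c1` gives 9.47. Compound 2 stands level with compound 3 at the digits shown, and the step of a number 0.19 log units higher from compound 1 to compound 2 (within the scatter) lies within the scatter, as do a number 0.19 log units higher from compound 1 to compound 3 (within the scatter) and no change at the digits printed from compound 2 to compound 3 (within the scatter). Compound 4 `COc1ccc(F)cc1CNCCCNc1ccnc2cc(CC(C)C)ccc12` is not yet measured. The change from compound 2 is 5-fluoro-2-methoxyphenyl in place of furan-2-yl on a saturated chain carbon bound to an amine nitrogen. For the measured compounds named here, none of the measured steps touches this position; all concern the substituent on the aromatic carbon, and none of them moved this assay beyond the scatter. A step of about a number 0.02 log units lower from compound 2 to compound 4 (within the scatter) is therefore expected, none beyond the scatter. For compound 4 the estimate in this assay is 9.45, within 9.1 to 9.8.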

Compound 4, acid dissociation constant: 9.47
The estimate for compound 4 lay 0.02 log units below the measured number; measured number inside the range.
By their numbers in this assay, from the lowest: compounds 1, 2, 3 and 4 (each within the scatter of the next).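

The earlier compounds shown here all carry furan-2-yl on the saturated chain carbon bound to an amine nitrogen, so this position had not been tested. In this assay the replacement by 5-fluoro-2-methoxyphenyl gives no change at the digits printed from compound 2 to compound 4 (within the scatter) and so stays within the scatter, though this rests on a single pair with isobutyl on the aromatic carbon. Nothing available accounts for this outcome.

As far as these compounds go, whether a basic amine or a carboxylic acid on the chain carbon's substituent would move the number in this assay remains open. So does whether the same replacement behaves alike alongside 2-methoxyphenoxy or isopentyl.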